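This account rests on a few compounds, and the source may have more. Where it says the series, first, only, none or still open, it means among the compounds named here.

Measured compounds in an ADME assay on microsomes from liver (Homo sapiens) for metabolic stability, read by LC-MS, using NADPH, with a stated time of 10 min, tested at 0.5 uM; on this read-out higher numbers stand for a more stable compound and lower numbers for a less stable compound:

compound 1 `COC(=O)Nc1cc(-c2ccc(OC[C@@](C)(N)CC(C)C)c(C)c2)ccn1` gives 98%
compound 2 `COC(=O)Nc1cc(-c2ccc(OC[C@@](C)(N)CC(C)C)nc2)ccn1` gives 100%
compound 3 `COC(=O)Nc1cc(-c2ccc(OC[C@@](C)(N)CC(C)C)c(C)c2C)ccn1` gives 93%

Compound 1 and compound 3 differ by one change, (methyl in place of hydrogen on an aromatic carbon), and the step is a number 5 percentage points lower from compound 1 to compound 3 (within the scatter). The difference between the core of compound 1 and the core of compound 2 is not broken down here. Compound 2 stands with the highest of the three numbers, but its gaps to compound 1 and to compound 3 are within the scatter, so no order among the three is claimed.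

Compound 4 `COC(=O)Nc1cc(-c2cnc(OC[C@@](C)(N)CC(C)C)cc2C)ccn1` is not yet measured. From compound 2 it differs by methyl in place of hydrogen on an aromatic carbon. Among the compounds with values here, this is the same kind of change as the one from compound 1 to compound 3, not the same change: in compound 3 the entering methyl sits on a six-membered aromatic ring of carbon only and ortho to a methyl group, whereas in compound 4 it sits on a six-membered aromatic ring with one nitrogen, opposite the ring nitrogen. In both cases it is ortho to a large group and meta to the (2-amino-2,4-dimethylpentyl)oxy group.

Within the data shown here, the expectation for compound 4 rests on the one measured instance of this kind of change, the step of a number 5 percentage points lower from compound 1 to compound 3 (within the scatter), which lay within the scatter. The step from compound 2 to compound 4 in this assay is accordingly expected to be a number 5 percentage points lower from compound 2 to compound 4 (within the scatter), of a similar size to the earlier one. Compound 4 is therefore estimated at 95%, with a range from 85% to 100%.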

Compound 4, percent of the compound remaining: 98%
Compound 4: the middle estimate sits 3 percentage points below what was measured; low and high end bracket the measured number.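

In this assay, methyl in place of hydrogen on an aromatic carbon can now be read on two cores, and the two steps do not differ: the same change on two cores in this assay, a number 5 percentage points lower (within the scatter) from compound 1 to compound 3 and a number 2 percentage points lower (within the scatter) from compound 2 to compound 4, 3 percentage points apart, within the scatter of two such steps

The new step is a number 2 percentage points lower from compound 2 to compound 4 (within the scatter), so on neither core does the change give a step that stands out from repeated measurement, and nothing here argues against carrying it from the core of compound 1 to the core of compound 2. This does not show that the change is without effect in general, since it rests on two pairs of compounds, the entering methyl sits on a differently built ring in each pair (opposite the ring nitrogen only in compound 4), and all the values lie close to the top of the scale, so the pairs give no view of how the change behaves on a less stable compound.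

The compounds shown leave open how this assay responds to other groups on that aromatic carbon, such as fluorine, chlorine, methoxy or an ethyl group. The (2-amino-2,4-dimethylpentyl)oxy group is also common to all four compounds, so a shorter chain or a replacement of its amine remains an open question.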